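Anilide ring substitution and maximal response in the series

This account rests on a few compounds, and the source may have more. Where it says the series, first, only, none or still open, it means among the compounds named here.

Compound 1 `O=C(CN1CCC(c2cccc[n+]2[O-])CC1)Nc1cccc(Cl)c1` stands highest of the three compounds measured in a functional assay on HEK293 cells for agonist activity at D(4) dopamine receptor (Homo sapiens), read by FLIPR (a lower number here means a smaller maximal response, a higher number a larger maximal response), where compound 1 gives 76%. Compound 2 `CC(C)Oc1cccc(NC(=O)CN2CCC(c3cccc[n+]3[O-])CC2)c1` gives 48%, and compound 3 `Cc1cccc(NC(=O)CN2CCC(c3ccccc3F)CC2)c1` gives 57%. For the measured compounds named here, the one single-point step in hand, a number 28 percentage points lower from compound 1 to compound 2 (beyond the scatter), shows that exchanging the substituent on the anilide ring can move the maximal response by a considerable margin.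

Compound 4 `O=C(CN1CCC(c2cccc[n+]2[O-])CC1)Nc1ccc(F)cc1` differs from compound 1 by 4-fluorophenyl in place of 3-chlorophenyl on an amide-type nitrogen. Going by the values given here, no measured pair covers this exact exchange; the step to compound 2 concerns a different substituent at a different place on the same ring, so it only indicates that this ring is sensitive, not the direction for a fluoro replacement. Compound 3 carries fluoro elsewhere and a different core, so its value cannot be read as a step.

Among the compounds with values here, for compound 4 a modest decrease in this assay is expected, a number 16 percentage points lower from compound 1 to compound 4 (beyond the scatter), because the only comparable ring change, a number 28 percentage points lower from compound 1 to compound 2 (beyond the scatter), lowered the response. The estimate for compound 4 is 60%, with a range from 40% to 80%.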

Compound 4, largest response reached (reported as efficacy), in percent of the reference or control that the assay uses: 71%
Estimate against measurement, compound 4: 11 percentage points below; the measured number falls inside the stated range.
By their numbers in this assay, from the lowest: compounds 2 and 3 (each within the scatter of the next); then compounds 4 and 1 (each within the scatter of the next).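

In this assay, 4-fluorophenyl in place of 3-chlorophenyl on an amide-type nitrogen gives no change that can be told from the scatter (a number 5 percentage points lower from compound 1 to compound 4 (within the scatter)), whereas the isopropoxy exchange gave a clear one (a number 28 percentage points lower from compound 1 to compound 2 (beyond the scatter)). The sensitivity of this ring therefore does not extend to every exchange: among the compounds shown, it appears with isopropoxy and not with this halogen exchange. This single step changes both the halogen and its place on the ring, so the two contributions cannot be separated, and no supporting measurement bears on the result.

Still open, from the compounds shown here alone, is whether 3-fluorophenyl or 4-chlorophenyl would behave like compound 1 and so separate the halogen from its place. Also open, going by these compounds, is where a ring carrying an amine or a carboxylic acid would fall.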